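A few compounds are considered here, and "the series" means these few. Any claim that something is new, unique, unknown or untested is made for them only; others in the source may bear on it.

Measured in a functional assay on KYSE-450 cells (Homo sapiens) for inhibition, read by MTT assay, with a stated time of 48 h; a lower number here means a stronger inhibitor, a higher number a weaker inhibitor:
Compound 1 `COc1ccc(CN(C(C)=O)c2cc(OC)c(OC)c(OC)c2)cc1O`: 160 nM
Compound 2 `C/C=C/C(=O)N(Cc1ccc(OC)c(OC)c1)c1cc(OC)c(OC)c(OC)c1`: 39100 nM

Compound 1 has the lower of these two numbers, and its gap to compound 2 lies well beyond the usual scatter. Compound 3 `C#CC(=O)N(Cc1ccc(OC)c(O)c1)c1cc(OC)c(OC)c(OC)c1` keeps the core of compound 1 and alters one group: ethynyl in place of methyl on a carbonyl carbon. In short, ethynyl stands in place of methyl on a carbonyl carbon. Going by the values given here, no measured pair shows this change alone, so any forecast remains loose. A moderate rise in this assay, meaning a weaker inhibitor and probably beyond the scatter, is expected: a 3.8-fold higher number from compound 1 to compound 3 (0.57 log units; beyond the scatter). For compound 3 the estimated value is 600 nM, with an expected range of 80 nM to 5000 nM.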

Compound 3, half-maximal inhibitory concentration: 570 nM
Beside the measured number, compound 3's estimate is 1.1-fold (0.02 log units) above it, within the range that was stated.
By their numbers in this assay, from the lowest: compound 1; then compound 3; then compound 2.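

In this assay, going by these compounds alone, the first reading of a single change at this position is a 3.6-fold higher number from compound 1 to compound 3 (0.55 log units; beyond the scatter). Ethynyl in place of methyl on a carbonyl carbon therefore costs some inhibition, but only a modest amount, so this carbon tolerates a triple bond. No supporting measurement explains the loss. The compounds shown leave open whether the shift depends on the triple bond or simply on the added carbon, which an ethyl or vinyl group at the same place could help separate. As far as these compounds go, how an amine there would behave also remains open.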